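This account rests on a few compounds, and the source may have more. Where it says the series, first, only, none or still open, it means among the compounds named here.

Compounds measured in a functional assay on NIH3T3 cells for agonist activity at Urotensin-2 receptor (Homo sapiens), with a stated time of 5 days (on this read-out lower numbers stand for smaller maximal responses and higher numbers for larger maximal responses), so far:
compound 1 `CN(C)CCC(NC(=O)C#Cc1ccccc1)c1ccc2ccccc2c1` gives 115%
compound 2 `COc1ccc(/C=C/C(=O)NC(CCN(C)C)c2ccc(C)cc2)cc1` gives 79%
compound 3 `CN(C)CCC(NC(=O)CCc1ccccc1)c1ccc2ccccc2c1` gives 107%

Compound 3 stands second highest of the three numbers. Its nearest neighbour is compound 1, reached by a number 8 percentage points lower from compound 1 to compound 3 (within the scatter), so the two are not told apart. Among the compounds with values here, compound 2 lies lower, and the gap to compound 3 is beyond the scatter; no single-point step links these two, as they differ in several places.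

Compound 4 `COc1ccc(CCC(=O)NC(CCN(C)C)c2ccc3ccccc3c2)cc1` differs from compound 3 by methoxy in place of hydrogen on an aromatic carbon. Within the data shown here, no measured step isolates methoxy in place of hydrogen on this ring, so no step size can be borrowed. Compound 2 carries a methoxy but also other changes, so its value is not a guide. The working expectation is therefore no step beyond the scatter, a number 5 percentage points lower from compound 3 to compound 4 (within the scatter). Compound 4 is estimated at 102%, with a range of 78% to 125%.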

Compound 4, largest response reached (reported as efficacy), in percent of the reference or control that the assay uses: 113%
The estimate for compound 4 lay 11 percentage points below the measured number, within the range that was stated.
By their numbers in this assay, from the lowest: compound 2; then compounds 3, 4 and 1 (each within the scatter of the next).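

In this assay, methoxy in place of hydrogen on an aromatic carbon, para to a large group, gives a number 6 percentage points higher from compound 3 to compound 4 (within the scatter). Within the data shown here, this is the first measured step for phenyl to 4-methoxyphenyl, and it shows that this position accepts the methoxy with no change in maximal response beyond the scatter. No measurement available here bears on why the response holds.

Still open, going by these compounds, is whether an amine or a carboxylic acid at this same position would also leave the maximal response within the scatter. A single step also leaves open whether a longer chain, such as ethoxy, would do the same.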